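The source may report more compounds than this note shows. Statements on the series, on what has been measured and on what is new or still open speak of the compounds shown alone.

Measured so far:
- compound 1, `CC(=O)CC/C=C(\C)CCC1=C(C)CCCC1(C)C`; in a functional assay on M14 cells (Homo sapiens) for inhibition (a higher number here means a weaker inhibitor of growth, a lower number a stronger inhibitor of growth), compound 1 gives < 1.5 nM, which is a limit of the assay, not a number
- compound 2, `C=C1CCCC(C)(C)C1(O)CC/C(C)=C/CC[C@]1(C)CC[C@@H]([C@@H](C)C(=O)OC)OO1`; in this assay compound 2 gives > 17500 nM, again a limit rather than a number
- compound 3, `C=C1CCCC(C)(C)C1CC[C@@]1(C)CC[C@H]([C@@H](C)C(=O)O)OO1`; in this assay compound 3 gives 12200 nM

Going by the values given here, compound 3 therefore stands as the only real number in the set; the other two values sit at the edges of what the assay reports, one at the limit of < 1.5 nM in this assay, at which 1 of the 3 values shown sits, and one at the limit of > 17500 nM in this assay, at which 1 of the 3 values shown sits. Among the compounds with values here, no pair of measured compounds differs in a single place, so no measured step is available to lean on.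

The next compound, compound 4, `C=C1CCCC(C)(C)C1CC[C@]1(C)CC[C@@H]([C@@H](C)C(=O)O)OO1`, is not yet measured. Its relation to compound 3 is the two compounds have the same atoms and bonds; at least one stereo element is drawn with a configuration in one of them and without one in the other: 2 of 4 stereo elements differ; a stereocentre at a saturated ring carbon is drawn S in compound 3 and R in compound 4; a stereocentre at a saturated ring carbon is drawn R in compound 3 and S in compound 4. The two compounds share every atom and bond; only the drawn configuration at two saturated ring carbons is inverted. Within the data shown here, with no measured step for any stereochemical change in this set, the expected step is one of uncertain direction and of a size not clearly beyond the scatter. The estimated step is a 1.0-fold lower number from compound 3 to compound 4 (0.01 log units; within the scatter). Compound 4 is expected to give about 12000 nM in this assay, within a range of 4000 nM to 35000 nM.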

Compound 4, concentration for 50% growth inhibition: > 10000 nM
Compound 4 gave a limit, no number; the forecaster's own chance of this, stated with the estimate: 25%; the middle value is on the limit's open side.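

The step between compound 3 and compound 4 cannot be read, because the result for compound 4 is a limit of the assay and not a number: the limit of > 10000 nM in this assay, at which 1 of the 4 values shown sits.

The compounds shown leave open whether inverting the two saturated ring carbons changes growth inhibition at all.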